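The compounds below may be only part of what the source reports. "The series", "measured", "known", "first", "only" and "open" are said of these compounds alone.

The shared core of this small series can be seen in compound 1 `O=C(Nc1ccccn1)c1cccc(Nc2ncc(F)c(Nc3ccc(F)cc3)n2)c1`, which carries a pyridin-2-yl group on an amide-type nitrogen, and in compound 2 `O=C(Nc1nccs1)c1cccc(Nc2ncc(F)c(Nc3ccc(F)cc3)n2)c1`, which carries a 1,3-thiazol-2-yl group there instead. In a functional assay on DU-145 cells (Homo sapiens) for antiproliferative activity, read by sulforhodamine B assay, with a stated time of 3 days (on this read-out higher numbers stand for weaker inhibition of growth and lower numbers for stronger inhibition of growth), compound 1 gives 15100 nM. Compound 2 reaches only the limit of the assay in this assay, at > 10000 nM; the step from compound 1 to compound 2 is therefore a step that the limit leaves unreadable from compound 1 to compound 2. Compound 3 `CN(C)CC(=O)Nc1cccc(Nc2ncc(F)c(Nc3ccc(F)cc3)n2)c1` replaces the whole carbamoyl arm and gives 1210 nM in this assay, a 12-fold lower number from compound 1 to compound 3 (1.10 log units; beyond the scatter) and an at least 8.2-fold lower number from compound 2 to compound 3 (0.91 log units; beyond the scatter).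

Compound 4 `O=C(NCCO)c1cccc(Nc2ncc(F)c(Nc3ccc(F)cc3)n2)c1` is not yet measured. Against compound 2 the change is 2-hydroxyethyl in place of 1,3-thiazol-2-yl on an amide-type nitrogen. Among the compounds with values here, of the measured steps, only the one from compound 1 to compound 2 concerns this amide-type nitrogen, and the limit leaves its size unreadable (the limit of > 10000 nM in this assay, at which 1 of the 3 values shown sits); the other two steps alter a different part of the structure. The account therefore has no measured guide for the size of the step in this assay, and the reader holding the new number may judge what this change brings.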

Compound 4, concentration for 50% growth inhibition: 13400 nM
The estimate for compound 4 lay 1.7-fold (0.22 log units) below the measured number, and the stated range covers the measured number.
By their numbers in this assay, from the lowest: compound 3; then compounds 4 and 1 (each within the scatter of the next).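

With the 2-hydroxyethyl group of compound 4, the amide-type nitrogen gets its first readable comparison in this assay, and it shows a 1.1-fold lower number from compound 1 to compound 4 (0.05 log units; within the scatter). On this evidence, a chain with no ring and the pyridin-2-yl ring are not told apart at this nitrogen, while exchanging the whole arm remains a large change, with an 11-fold higher number from compound 3 to compound 4 (1.04 log units; beyond the scatter). The step from compound 2 to compound 4 cannot be read, since the value of compound 2 is a limit: the limit of > 10000 nM in this assay, at which 1 of the 4 values shown sits.

Going by these compounds, whether a 2-(dimethylamino)ethyl chain on this amide-type nitrogen would bring the number closer to that of compound 3 remains open. Also open, on these data alone, is whether a longer chain ending in a hydroxyl group, or a carboxylic acid in its place, would move the number at all.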